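From Propargyl Ether to Trifluoromethylbenzyl Ether on the Shared Core

A few compounds are considered here, and "the series" means these few. Any claim that something is new, unique, unknown or untested is made for them only; others in the source may bear on it.

Within the data shown here, compound 1 `C#CCOc1ccc2c(=O)c(-c3cc(OC)c(OC)cc3OC)coc2c1` stands second highest of the three numbers measured so far in a functional assay on U-251 cells (Homo sapiens) for antiproliferative activity, read by MTT assay, with a stated time of 24 h (a lower number here means a stronger inhibitor, a higher number a weaker inhibitor), where compound 1 gives 6450 nM. Compound 2 `COc1cc(OC)c(-c2coc3cc(OCc4ccc(Br)cc4)ccc3c2=O)cc1OC` gives 10000 nM and compound 3 `COc1cc(OC)c(-c2coc3cc(OCc4ccc(Cl)cc4)ccc3c2=O)cc1OC` gives 470 nM. The change to compound 4 `COc1cc(OC)c(-c2coc3cc(OCc4cccc(C(F)(F)F)c4)ccc3c2=O)cc1OC` is 3-(trifluoromethyl)phenyl in place of ethynyl on a saturated chain carbon bound to an oxygen on an aromatic ring. Among the measured compounds shown here, two measured steps bear on it, each replacing the same ethynyl with an aryl group: a 1.6-fold higher number from compound 1 to compound 2 (0.19 log units; within the scatter), whereas a 14-fold lower number from compound 1 to compound 3 (1.14 log units; beyond the scatter); the two aryl products differ widely between themselves, as a 21-fold lower number from compound 2 to compound 3 (1.33 log units; beyond the scatter). A 3-(trifluoromethyl)phenyl is a third such group, so a step in either direction is possible, with the lower side somewhat favoured. Compound 4 is therefore expected to show a 2.6-fold lower number from compound 1 to compound 4 (0.41 log units; beyond the scatter), an estimated 2500 nM with a range from 500 nM to 12000 nM.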

Compound 4, half-maximal inhibitory concentration: > 10000 nM
Compound 4: a limit, no number (the forecaster's own chance of this, stated with the estimate: 15%); middle value at least 4.0-fold (0.60 log units) from the limit.
By their numbers in this assay, from the lowest: compound 3; then compounds 1 and 2 (each within the scatter of the next).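

Compound 4 is recorded only as a limit of the assay, not as a number: the limit of > 10000 nM in this assay, at which 1 of the 4 values shown sits. The change is large when measured against the 4-chlorophenyl, with an at least 21-fold higher number from compound 3 to compound 4 (1.32 log units; beyond the scatter), whereas an at least 1.5-fold higher number from compound 1 to compound 4 (0.19 log units; that floor lies within the scatter) shows no lowering relative to ethynyl, so replacing ethynyl with an aryl group at this position does not by itself lower the number, and compound 3 goes against that trend. Against the 4-bromophenyl the record gives a number no lower from compound 2 to compound 4 (the limit leaves the size open) and the size of that step cannot be read.

As far as these compounds go, it remains open whether the low number of compound 3 depends on the chloro group or on its ring position. Also open, from the compounds shown here alone, is what an unsubstituted benzyl, or an amine or carboxylic acid on that ring, would give.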